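A bromo in place of methoxy on the anilino ring

The compounds below may be only part of what the source reports. "The series", "measured", "known", "first", "only" and "open" are said of these compounds alone.

Compound 1 `COc1ccc(NC2=CC(=O)c3c(nc4n3[C@H]3OC[C@@H](O)[C@H]3OC4)C2=O)cc1` carries a methoxy on the aromatic ring attached through nitrogen to the shared core. For the measured compounds named here, in a functional assay on MCF7 cells (Homo sapiens) for inhibition, read by sulforhodamine B assay (a higher number here means a weaker inhibitor, a lower number a stronger inhibitor), compound 1 gives 4470 nM, the higher of the two numbers known so far. Compound 2 `CCc1ccc(NC2=CC(=O)c3nc4n(c3C2=O)[C@H]2OC[C@@H](O)[C@H]2OC4)cc1`, the nearest neighbour, bears ethyl in place of that methoxy and gives 960 nM in this assay. Compound 3 `O=C1C=C(Nc2ccccc2)C(=O)c2c1nc1n2[C@H]2OC[C@@H](O)[C@H]2OC1` carries hydrogen there, and in this assay compound 3 reaches only the limit of > 4000 nM, which is a limit of the assay and not a number (the limit of > 4000 nM in this assay, at which 1 of the 3 values shown sits). Going by the values given here, the single measured step, an at least 4.1-fold higher number from compound 2 to compound 3 (0.61 log units; beyond the scatter), shows that what stands on this aromatic carbon can move the number beyond the scatter.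

Compound 4 `O=C1C(Nc2ccc(Br)cc2)=CC(=O)c2c1nc1n2[C@H]2OC[C@@H](O)[C@H]2OC1` differs from compound 1 by bromo in place of methoxy on an aromatic carbon. Among the compounds with values here, no measured step exchanges a methoxy for a bromo, so the step from compound 2 to compound 3 is the only guide to how much a change on that aromatic carbon can do. On this basis compound 4 is expected to give 1800 nM, with a likely range from 600 nM to 5000 nM. The expected step is a 2.5-fold lower number from compound 1 to compound 4 (0.40 log units; beyond the scatter), with a real chance that only a limit is reported.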

Compound 4, half-maximal inhibitory concentration: 4330 nM
Beside the measured number, compound 4's estimate is 2.4-fold (0.38 log units) below it; measured number inside the range.
By their numbers in this assay, from the lowest: compound 2; then compounds 4 and 1 (each within the scatter of the next).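

In this assay, bromo in place of methoxy on this aromatic carbon gives a 1.0-fold lower number from compound 1 to compound 4 (0.01 log units; within the scatter), so this exchange, unlike the one measured earlier on the same carbon, leaves the number where it was. The position therefore does not respond to every change: methoxy and bromo differ in their atoms and in their hydrogen-bond acceptors yet read alike, while compound 2, with ethyl, gives 960 nM, the lowest number shown. The value of compound 3 is a limit of the assay and not a number, so hydrogen cannot be placed against these groups: the limit of > 4000 nM in this assay, at which 1 of the 4 values shown sits.

The compounds shown leave open whether the lower number stays with ethyl alone or extends to a longer chain such as propyl. They also leave open how an amine or a carboxylic acid would read on this carbon.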